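The compounds below may be only part of what the source reports. "The series", "measured", "known", "first", "only" and "open" are said of these compounds alone.

Compound 1 `COc1ccc(-c2nc(N=C(N)N)sc2-c2ccc(OC)cc2)cc1`: 2 uM
Compound 2 `COc1ccc(-c2nc(/N=C(\N)NC(C)C)sc2-c2ccc(OC)cc2)cc1`: 9.1 uM
Compound 3 `COc1ccc(-c2nc(/N=C(\N)N(C)C)sc2-c2ccc(OC)cc2)cc1`: 4.8 uM

Compound 3 has one close neighbour and one more distant neighbour in a functional assay (aorta) with Rattus norvegicus as the target; on this read-out lower numbers stand for an effect already at smaller amounts and higher numbers for an effect only at larger amounts of compound: a 1.9-fold lower number from compound 2 to compound 3 (0.28 log units; within the scatter), against a 2.4-fold higher number from compound 1 to compound 3 (0.38 log units; beyond the scatter). The next compound, compound 4 `COc1ccc(-c2nc(/N=C(\N)NC3CCCCC3)sc2-c2ccc(OC)cc2)cc1`, has cyclohexylamino in place of dimethylamino on a carbon with a double bond to nitrogen. The nearest measured group is the isopropylamino of compound 2, and introducing it gave a 4.6-fold higher number from compound 1 to compound 2 (0.66 log units; beyond the scatter). For the measured compounds named here, no measured compound carries a ring at this place, so any forecast is uncertain. A modest rise in this assay is expected, with the estimated step being a 2.1-fold higher number from compound 3 to compound 4 (0.32 log units; beyond the scatter). Compound 4 is estimated at 10 uM, within an expected range of 4 uM to 25 uM.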

Compound 4, concentration for half-maximal effect: > 100 uM
Compound 4: only a limit was reported; the forecaster's own chance of this, stated with the estimate: 3%; middle value at least 10-fold (1.00 log units) away from the limit.
By their numbers in this assay, from the lowest: compound 1; then compounds 3 and 2 (each within the scatter of the next). At a limit, above all of these: compound 4.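

In this assay compound 4 gives > 100 uM, which is a limit and not a number. The steps are therefore minimum sizes: an at least 20-fold higher number from compound 3 to compound 4 (1.31 log units; beyond the scatter), an at least 10-fold higher number from compound 2 to compound 4 (1.04 log units; beyond the scatter), and an at least 50-fold higher number from compound 1 to compound 4 (1.69 log units; beyond the scatter). The earlier changes at this place were modest, so the carbon with a double bond to nitrogen does not accept every group equally, and cyclohexyl has a large effect where isopropyl had a modest one.

On these data alone, whether the ring itself or simply the larger group matters stays open; a cyclopropyl group or a straight hexyl chain here would separate the two. How far compound 4 lies beyond its limit is also unknown.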